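Chain Extension of a Chlorobenzyl Hydroxamate HDAC6 Inhibitor

The source may report more compounds than this note shows. Statements on the series, on what has been measured and on what is new or still open speak of the compounds shown alone.

Compound 1 `CS(=O)(=O)c1ccc(-n2ccc3cnc(Nc4cnn(CCCCCCC(=O)NO)c4)nc32)cc1`: 5.9 nM
Compound 2 `O=C(CCCCCCn1cc(Nc2ncc3ccn(Cc4ccccc4F)c3n2)cn1)NO`: 8.4 nM
Compound 3 `O=C(CCCCCn1cc(Nc2ncc3ccn(Cc4ccccc4Cl)c3n2)cn1)NO`: 45 nM

In an assay on isolated protein for inhibition of protein deacetylase HDAC6 (Homo sapiens), with a stated time of 60 min (a lower number here means a stronger inhibitor, a higher number a weaker inhibitor), compound 3 gives the highest of the three numbers; its gap to compound 2 and its gap to compound 1 both lie beyond the scatter, so compound 3 is the weakest inhibitor of the three. Compound 4 `O=C(CCCCCCn1cc(Nc2ncc3ccn(Cc4ccccc4Cl)c3n2)cn1)NO` is the untested analogue in which ((hydroxycarbamoyl)methyl in place of hydroxycarbamoyl on a saturated chain carbon, five bonds along the chain from an aromatic nitrogen); cut one bond further out, the same difference reads (hydroxycarbamoyl)methyl to 2-(hydroxycarbamoyl)ethyl, and so on along the chain. Compound 4 thus carries the same chain length as compound 1 and compound 2, with the 2-chlorobenzyl of compound 3.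

Among the compounds with values here, the only measured step, a 1.4-fold higher number from compound 1 to compound 2 (0.15 log units; within the scatter), concerns a different place and says nothing about the chain. Within the data shown here, no measured pair isolates the chain alone, since compound 2 and compound 3 differ in two places. What the values show is that the two longer-chain compounds sit well below compound 3 in this assay. On that basis compound 4 is expected to give a lower number than compound 3, a step of about a 4.5-fold lower number from compound 3 to compound 4 (0.65 log units; beyond the scatter). The estimate for compound 4 in this assay is 10 nM, within a range from 4 nM to 25 nM.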

Compound 4, half-maximal inhibitory concentration: 41.5 nM
Beside the measured number, compound 4's estimate is 4.2-fold (0.62 log units) below it; measured number above the stated range.
By their numbers in this assay, from the lowest: compounds 1 and 2 (each within the scatter of the next); then compounds 4 and 3 (each within the scatter of the next).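

In this assay, putting (hydroxycarbamoyl)methyl in place of hydroxycarbamoyl, on a saturated chain carbon five bonds along the chain from an aromatic nitrogen, gives a 1.1-fold lower number from compound 3 to compound 4 (0.04 log units; within the scatter), so with the 2-chlorobenzyl group these two chain lengths cannot be told apart. At the longer chain length, the group on the other side of the molecule does separate the compounds: chloro in place of fluoro on an aromatic carbon gives a 4.9-fold higher number from compound 2 to compound 4 (0.69 log units; beyond the scatter), and swapping 4-(methylsulfonyl)phenyl for 2-chlorobenzyl gives a 7.0-fold higher number from compound 1 to compound 4 (0.85 log units; beyond the scatter), both modest steps in this assay. No supporting data are available to explain why the chloro and fluoro compounds differ or why the chain change leaves the number within the scatter.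

The compounds shown leave open whether chain length matters with a 2-fluorobenzyl or 4-(methylsulfonyl)phenyl group, since each of these appears at one chain length only. They also leave open how a longer chain, a bromo or methoxy group in place of the chloro, or a carboxylic acid in place of the hydroxycarbamoyl would read in this assay.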